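Adding an Isopropylcarbonyl Group to an Aryl-Piperazine Ligand

This account rests on a few compounds, and the source may have more. Where it says the series, first, only, none or still open, it means among the compounds named here.

Compound 1 `COc1ccc(Cl)cc1N1CCN(CCCCNc2c(C(C)=O)c(C)nn(C)c2=O)CC1`: 49.1 nM
Compound 2 `COc1ccccc1N1CCN(CCNc2cc(-c3ccccc3)nn(C)c2=O)CC1`: 2.01 nM
Compound 3 `COc1ccc(Cl)cc1N1CCN(CCNc2c(C(C)=O)c(-c3ccccc3)nn(C)c2=O)CC1`: 3.95 nM

In an assay on isolated protein for binding affinity to Alpha-1B adrenergic receptor (Homo sapiens), read by radioligand binding (on this read-out higher numbers stand for weaker inhibition and lower numbers for stronger inhibition), compound 2 gives the lowest number of the three. Compound 3 gives a value that lies within the scatter of this assay compared with compound 2, while compound 1 sits far higher, beyond the scatter. Compound 4 `COc1ccccc1N1CCN(CCNc2c(C(=O)C(C)C)c(-c3ccccc3)nn(C)c2=O)CC1` is obtained from compound 2 by one change: isopropylcarbonyl in place of hydrogen on an aromatic carbon. For the measured compounds named here, no measured pair shows this exact step, but compound 3 already carries a carbonyl group at this place and shows a number close to compound 2. The expected step from compound 2 to compound 4 in this assay is therefore small, a 1.5-fold higher number from compound 2 to compound 4 (0.17 log units; within the scatter), none beyond the scatter. Compound 4 is estimated at 3 nM, in the range 1 nM to 10 nM.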

Compound 4, inhibition constant: 0.64 nM
Compound 4: middle estimate off by 4.7-fold (0.67 log units), on the high side; the whole stated range lies above it.
By their numbers in this assay, from the lowest: compound 4; then compounds 2 and 3 (each within the scatter of the next); then compound 1.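

In this assay, the aromatic carbon ortho to a phenyl group accepts more than hydrogen: isopropylcarbonyl there gives a 3.1-fold lower number from compound 2 to compound 4 (0.50 log units; beyond the scatter), a modest step that lies beyond the scatter. Among the compounds that differ only at this place, a group of 5 heavy atoms therefore improves on hydrogen rather than merely being accepted. No measurement shown here gives a reason for this step. On these data alone, whether the carbonyl or the isopropyl part carries the step stays open, as does the effect of an amine or a carboxylic acid at this place.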